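The source may hold more compounds than are shown below. What is called first, only, known or untested is meant among the compounds shown, and "the series" means these compounds.

Measured so far:
compound 1 `C=CCONC(=O)Cn1cc(C(=O)N[C@@H](C)C(=O)N[C@H](C(=O)O)C(C)C)c2ccccc21`: > 128000 nM
compound 2 `CC(C)[C@H](NC(=O)CNC(=O)c1cn(CC(=O)NOCc2ccccc2)c2ccccc12)C(=O)O`: > 128000 nM

In a functional assay on MRC5 cells (Homo sapiens) for inhibition, read by microscopy and resazurin assay, with a stated time of 72 h (on this read-out higher numbers stand for weaker inhibition and lower numbers for stronger inhibition), compound 2 gives only a limit, > 128000 nM. Compound 1 likewise returns only a limit in this assay, > 128000 nM. Both values sit at the limit of > 128000 nM in this assay, at which 2 of the 2 values shown sit, so no ordering between the two can be drawn. Compound 3 `CC(C)[C@H](NC(=O)[C@H](C)NC(=O)c1cn(CC(=O)NOCc2ccccc2)c2ccccc12)C(=O)O` is not yet measured in this assay. It differs from compound 2 by methyl in place of hydrogen on a saturated chain carbon bound to an amide-type nitrogen and a carbonyl carbon. Compound 1 already carries this methyl and gives a limit, > 128000 nM, in this assay. Hence no step beyond the scatter is expected a step that the limit leaves unreadable from compound 2 to compound 3. Compound 3 is expected at 160000 nM, between 60000 nM and 500000 nM, most likely again reported only as a limit.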

Compound 3, half-maximal inhibitory concentration: > 128000 nM
Compound 3 was reported as a limit; the forecaster's own chance of this, stated with the estimate: 85%; the middle value does not contradict the limit.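

No step can be read from compound 1 or compound 2 to compound 3, as all three values are limits: the limit of > 128000 nM in this assay, at which 3 of the 3 values shown sit. The compounds shown leave open whether methyl in place of hydrogen, or phenyl in place of vinyl, changes inhibition at all.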